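This account rests on a few compounds, and the source may have more. Where it says the series, first, only, none or still open, it means among the compounds named here.

Working notes on the series. Three compounds on the shared core have been run in a functional assay on MDA-MB-231 cells (Homo sapiens) for antiproliferative activity, read by MTT assay, with a stated time of 72 h; on this read-out lower numbers stand for stronger inhibition and higher numbers for weaker inhibition: compound 1 `O=C(Nc1ccc(-c2noc(-c3cccc(NS(=O)(=O)c4ccc(C(F)(F)F)cc4)c3)n2)c(Cl)c1)c1cccnc1`, compound 2 `O=C(Nc1ccc(-c2noc(-c3cccc(NS(=O)(=O)c4ccc(NC(=O)N5CCOCC5)cc4)c3)n2)c(Cl)c1)c1cccnc1` and compound 3 `O=C(Nc1ccccc1)Nc1cccc(-c2nc(-c3ccc(NC(=O)c4cccnc4)cc3Cl)no2)c1`. Compound 1 returns only a limit of the assay, > 10000 nM. Compound 2 likewise returns only a limit, > 10000 nM. Compound 3 also returns only a limit, > 10000 nM. Compound 3 therefore stands at the same limit as every other measured compound, (the limit of > 10000 nM in this assay, at which 3 of the 3 values shown sit), and no number places it above or below them. Within the data shown here, the single one-place step that has been measured, a step that the two limits leave unreadable from compound 1 to compound 2, cannot be read, both of its ends being limits.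

Compound 4 `CS(=O)(=O)Nc1cccc(NC(=O)Nc2cccc(-c3nc(-c4ccc(NC(=O)c5cccnc5)cc4Cl)no3)c2)c1` differs from compound 3 by methanesulfonamido in place of hydrogen on an aromatic carbon. Among the measured compounds shown here, no measured step bears directly on this change, and the sole step available is unreadable, so nothing in the data points to a direction. All three measured compounds sit at the limit, leaving no trend to extend. Compound 4 is accordingly expected to remain near that limit, and the step is estimated as an at least 1.1-fold lower number from compound 3 to compound 4 (0.04 log units; that floor lies within the scatter). For compound 4 the expected value in this assay is 9000 nM, with a range from 2000 nM to 30000 nM.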

Compound 4, half-maximal inhibitory concentration: > 10000 nM
Compound 4: only a limit was reported (the forecaster's own chance of this, stated with the estimate: 70%); middle value at least 1.1-fold (0.04 log units) from the limit.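

Among these compounds, the step from compound 3 to compound 4 cannot be read, both of its ends being limits, so compound 4 adds no new readable step to the series. The compounds shown leave open how any change on the shared core moves antiproliferative activity, as all of them sit at one value: the limit of > 10000 nM in this assay, at which 4 of the 4 values shown sit.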